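Series notes: fluoro on the pendant phenyl of compound 1

The compounds below may be only part of what the source reports. "The series", "measured", "known", "first", "only" and "open" are said of these compounds alone.

Compound 1 `NS(=O)(=O)NCCC1CCN(c2cc(-c3ccccc3)ncn2)CC1` is the parent of the set. In a functional assay on MCF7 cells (Homo sapiens) for antiproliferative activity, read by sulforhodamine B assay, with a stated time of 48 h (a lower number here means a stronger inhibitor of growth, a higher number a weaker inhibitor of growth), compound 1 gives 53200 nM, the highest of the three numbers measured. Its nearest neighbour is compound 2 `COC(=O)c1ccc(-c2cc(N3CCC(CCNS(N)(=O)=O)CC3)ncn2)cc1`, which in this assay gives 17600 nM; the furthest is compound 3 `CCOC(=O)c1ccc(-c2cc(N3CCC(CCNS(N)(=O)=O)CC3)ncn2)cc1`, which gives 6200 nM. The measured steps are a 3.0-fold lower number from compound 1 to compound 2 (0.48 log units; beyond the scatter), an 8.6-fold lower number from compound 1 to compound 3 (0.93 log units; beyond the scatter) and a 2.8-fold lower number from compound 2 to compound 3 (0.45 log units; beyond the scatter); all three concern an ester placed on the pendant phenyl and are modest in size.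

Compound 4 `NS(=O)(=O)NCCC1CCN(c2cc(-c3ccccc3F)ncn2)CC1` differs from compound 1 by fluoro in place of hydrogen on an aromatic carbon, read one bond further out as phenyl to 2-fluorophenyl. Within the data shown here, no measured step touches this position or this group. The only bearing is indirect: the steps from compound 1 to compound 2 and to compound 3 show that the pendant phenyl tolerates substitution with a lower number, but those groups are far larger than a single fluorine. A step of at most small size, if any, is expected in this assay, probably toward a lower number, and it may well sit within the scatter. The estimate for compound 4 is 40000 nM, with a range from 15000 nM to 110000 nM, which amounts to an expected step of a 1.3-fold lower number from compound 1 to compound 4 (0.12 log units; within the scatter).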

Compound 4, concentration for 50% growth inhibition: > 100000 nM
Compound 4 gave a limit, no number; the forecaster's own chance of this, stated with the estimate: 15%; middle value at least 2.5-fold (0.39 log units) away from the limit.
By their numbers in this assay, from the lowest: compound 3; then compound 2; then compound 1. At a limit, above all of these: compound 4.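

Compound 4 stands at a limit of the assay, not at a number: the limit of > 100000 nM in this assay, at which 1 of the 4 values shown sits. The step reads an at least 1.8-fold higher number from compound 1 to compound 4 (0.27 log units; that floor lies within the scatter), so it has only a floor, and that floor does not by itself separate compound 4 from compound 1. Compounds 2 and 3 showed only lower numbers for a change on the pendant phenyl, whereas fluoro on an aromatic carbon, ortho to a large group, gives no sign of a lower number in this assay, so the trend of the esters does not extend to 2-fluorophenyl.

Going by these compounds, how far compound 4 lies beyond the limit stays open. Also open, on these data alone, is whether this reading belongs to fluoro itself or to any group at this place, which a methyl, a chloro or an amine on the same aromatic carbon would help to settle.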